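A few compounds are considered here, and "the series" means these few. Any claim that something is new, unique, unknown or untested is made for them only; others in the source may bear on it.

In a functional assay on DU-145 cells (Homo sapiens) for inhibition, read by trypan blue exclusion, with a stated time of 72 h (on this read-out higher numbers stand for weaker inhibition and lower numbers for stronger inhibition), compound 1 `COc1ccc(S(=O)(=O)c2cc3cnc(Nc4cccc5[nH]ccc45)nc3n(C)c2=O)cc1` gives 5000 nM, while compound 2 `Cn1c(=O)c(S(=O)(=O)c2ccc(F)cc2)cc2cnc(Nc3cccc4[nH]ccc34)nc21` gives 750 nM, the lower of the two numbers. Compound 3 `Cc1ccc(S(=O)(=O)c2cc3cnc(Nc4cccc5[nH]ccc45)nc3n(C)c2=O)cc1` differs from compound 2 by methyl in place of fluoro on an aromatic carbon, with methyl in place of fluoro on an aromatic carbon. For the measured compounds named here, the only measured step that bears on this change is a 6.7-fold lower number from compound 1 to compound 2 (0.82 log units; beyond the scatter), a modest one with fluoro in place of methoxy on an aromatic carbon. A modest rise in the number is therefore expected, somewhat smaller than that step. The expected step is a 2.0-fold higher number from compound 2 to compound 3 (0.30 log units; within the scatter). Compound 3 is estimated at 1500 nM, with an expected range from 500 nM to 4500 nM.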

Compound 3, half-maximal inhibitory concentration: 10000 nM
The estimate for compound 3 lay 6.7-fold (0.82 log units) below the measured number; measured number outside the range, above it.
By their numbers in this assay, from the lowest: compound 2; then compounds 1 and 3 (each within the scatter of the next).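

In this assay, the change from 4-fluorophenyl to 4-methylphenyl gives a 13-fold higher number from compound 2 to compound 3 (1.12 log units; beyond the scatter), a large step that is bigger than the earlier fluoro-for-methoxy step. Methyl and methoxy are not separated at this position, with a 2.0-fold higher number from compound 1 to compound 3 (0.30 log units; within the scatter), so among these three compounds only the fluoro compound stands apart, with the lowest number. From the compounds shown here alone, whether chloro, a nitrile or an amine at this place would match or improve on fluoro stays open, as does the number with plain hydrogen there. No measurement at hand explains why fluoro differs from the other two groups.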